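Nitro substitution on the aryl piperazine in two bicyclic cores

The compounds below may be only part of what the source reports. "The series", "measured", "known", "first", "only" and "open" are said of these compounds alone.

Measured compounds:
compound 1, `O=C1C2CCCN2C(=O)N1CN1CCN(c2ccccc2)CC1`, 2590 nM
compound 2, `O=C1C2CCCN2C(=O)N1CN1CCN(c2ccc([N+](=O)[O-])cc2)CC1`, 260000 nM
compound 3, `O=C1C2CCCCN2C(=O)N1CN1CCN(c2ccccc2)CC1`, 2080 nM

In an assay on Cerebral cortex for binding affinity to Adrenergic receptor alpha-1 (Rattus norvegicus), read by radioligand binding (on this read-out lower numbers stand for stronger inhibition and higher numbers for weaker inhibition), compound 1 gives 2590 nM and compound 3 gives 2080 nM; these two values lie within the scatter of each other, and the difference between the two cores is not broken down here. Compound 2 differs from compound 1 by nitro in place of hydrogen on an aromatic carbon, and this produces a 100-fold higher number from compound 1 to compound 2 (2.00 log units; beyond the scatter).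

Compound 4, `O=C1C2CCCCN2C(=O)N1CN1CCN(c2ccc([N+](=O)[O-])cc2)CC1`, is not yet measured. It differs from compound 3 by nitro in place of hydrogen on an aromatic carbon, the same change as that from compound 1 to compound 2, made at the same place and with the same group entering. Within the data shown here, only one prior instance of this change is available, so the expectation rests on a single step. Because a 100-fold higher number from compound 1 to compound 2 (2.00 log units; beyond the scatter) was large, the step of a 96-fold higher number from compound 3 to compound 4 (1.98 log units; beyond the scatter) is expected to be of similar size. Compound 4 is therefore estimated at 200000 nM in this assay, with a plausible range from 50000 nM to 600000 nM.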

Compound 4, inhibition constant: 260000 nM
Beside the measured number, compound 4's estimate is 1.3-fold (0.11 log units) below it; the range from low to high includes it.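

In this assay, the change from phenyl to 4-nitrophenyl on the core of compound 3 gives a 130-fold higher number from compound 3 to compound 4 (2.10 log units; beyond the scatter), and it matches the step seen on the core of compound 1: the same change on two cores in this assay, a 100-fold higher number (2.00 log units; beyond the scatter) from compound 1 to compound 2 and a 130-fold higher number (2.10 log units; beyond the scatter) from compound 3 to compound 4, 1.2-fold (0.10 log units) apart, within the scatter of two such steps

The change therefore carries across these two cores with its size preserved, and in this series the core of compound 1 and the core of compound 3 can be treated alike for this one substitution in this assay. This rests on a single pair per core, with one group at one place, so it neither explains why the step is so large nor shows that a third core would behave the same way.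

As far as these compounds go, it remains open whether the large step belongs to nitro itself or would also follow another group at that place, such as an amine, a nitrile or a carboxylic acid. Also open, from the compounds shown here alone, is whether nitro on another carbon of the same aromatic ring would give a step of this size.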